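Capsaicinoid amides: hydroxyheptyl chain variant of compound 2

The source may report more compounds than this note shows. Statements on the series, on what has been measured and on what is new or still open speak of the compounds shown alone.

Three compounds carry the shared core seen in compound 1 `COc1cc(CNC(=O)/C=C(\C)CCC[C@H](C)CCC[C@H](C)CCCC(C)C)ccc1O` and differ only in the acyl chain. In a functional assay on HEK293 cells with transient receptor potential cation channel subfamily V member 1 (Homo sapiens) as the target (a lower number here means that less compound is needed, a higher number that more compound is needed for the effect), compound 1 gives 2 nM. Compound 2 `CCCCCCCC/C=C\CCCCCCCCCCC(=O)NCc1ccc(O)c(OC)c1` has the highest number of the three; in this assay compound 2 gives 3.16 nM, which lies within the scatter of compound 1 and so cannot be ordered against it. Compound 3 `CCCCCC[C@H](C/C=C\CCCCCCCC(=O)NCc1ccc(O)c(OC)c1)OC(C)=O` carries an acetoxy group on its chain, and in this assay compound 3 gives 0.398 nM, a gap to compound 2 that is beyond the scatter.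

Compound 4 `CCCCCC[C@@H](O)CCCCCCCCCCC(=O)NCc1ccc(O)c(OC)c1` is the next variant. It differs from compound 2 as follows: 1-hydroxyheptyl in place of dec-1-en-1-yl on a saturated chain carbon, ten or more bonds along the chain from a carbonyl carbon. For the measured compounds named here, no measured pair shows this change in isolation, so its size can only be expected. Compound 4 is expected near the values of compound 1 and compound 2, with no step beyond the scatter: the step from a 1.3-fold higher number from compound 2 to compound 4 (0.10 log units; within the scatter) is the estimate. For compound 4 the expected value in this assay is 4 nM, with a range from 1 nM to 16 nM.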

Compound 4, half-maximal effective concentration: 5.01 nM
Beside the measured number, compound 4's estimate is 1.3-fold (0.10 log units) below it; measured number inside the range.
By their numbers in this assay, from the lowest: compound 3; then compounds 1, 2 and 4 (each within the scatter of the next, the first and the last beyond it).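

In this assay, 1-hydroxyheptyl in place of dec-1-en-1-yl on a saturated chain carbon, ten or more bonds along the chain from a carbonyl carbon, gives a 1.6-fold higher number from compound 2 to compound 4 (0.20 log units; within the scatter). For the compounds shown here, this is the first pair that differs in one place, and it shows that this part of the chain can lose its double bond and take on a hydroxyl group and a defined stereocentre with no step beyond the scatter. Nothing at hand accounts for the size of this step.

The exchange changes chain length, the double bond and the hydroxyl group at once, so their separate contributions remain unresolved. As far as these compounds go, the opposite configuration at the hydroxyl carbon also remains open, as does the outcome with an amine or a methoxy group on that carbon.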